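A Second Chlorine on the Benzyl Ring

The source may hold more compounds than are shown below. What is called first, only, known or untested is meant among the compounds shown, and "the series" means these compounds.

In a functional assay on MCF7 cells (Homo sapiens) for antiproliferative activity, read by MTT assay, with a stated time of 48 h, in the presence of a further agent that is not named here (a lower number here means a stronger inhibitor of growth, a higher number a weaker inhibitor of growth), compound 2 `O=C(NOCc1ccccc1Cl)c1cn(-c2ccccc2)nc1-c1ccccc1` gives 7410 nM. Going by the values given here, it carries the lower of the two numbers measured so far, yet its only neighbour, compound 1 `O=C(NOCc1ccccc1)c1cn(-c2ccccc2)nc1-c1ccccc1`, gives 13400 nM, and the step of a 1.8-fold lower number from compound 1 to compound 2 (0.26 log units; within the scatter) lies within the usual scatter, so no real difference between the two can be claimed. Compound 3 `O=C(NOCc1ccc(Cl)cc1Cl)c1cn(-c2ccccc2)nc1-c1ccccc1` has not been measured. It differs from compound 2 in one place: chloro in place of hydrogen on an aromatic carbon. Among the compounds with values here, the only measured step that bears on this change is the one from compound 1 to compound 2, which also put a chloro group on an aromatic carbon and produced a difference too small to count. A second chloro group is therefore expected to change little, at most nudging the number down, with a 1.3-fold lower number from compound 2 to compound 3 (0.13 log units; within the scatter) as the estimated step. Compound 3 is expected to give about 5500 nM in this assay, most likely between 2200 nM and 14000 nM.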

Compound 3, concentration for 50% growth inhibition: 9660 nM
The estimate for compound 3 lay 1.8-fold (0.24 log units) below the measured number, and the stated range covers the measured number.
By their numbers in this assay, from the lowest: compounds 2, 3 and 1 (each within the scatter of the next).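

Adding the second chloro group, para to a large group and meta to a chloro group, gives a 1.3-fold higher number from compound 2 to compound 3 (0.12 log units; within the scatter) and so does not set the two compounds apart in this assay. With both chloro groups counted together, 2,4-dichlorophenyl in place of phenyl gives a 1.4-fold lower number from compound 1 to compound 3 (0.14 log units; within the scatter), so compounds 1, 2 and 3 cannot be told apart by their numbers, and chloro at either place on this ring has shown no measurable effect. No measurement at hand offers an explanation for these numbers.

Still open, going by these compounds, is whether a different group at the same place, such as a methoxy group, an amine or a carboxylic acid, would give a step beyond the scatter. The compounds shown also leave open what chloro would do on either of the two phenyl groups of the shared core.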